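Notes on the aryl change from compound 3 to compound 4

A few compounds are considered here, and "the series" means these few. Any claim that something is new, unique, unknown or untested is made for them only; others in the source may bear on it.

Three compounds built on the shared core have numbers in a functional assay on mitochondria from heart for inhibition of peroxisomal acyl-coenzyme A oxidase 1 (Rattus norvegicus); on this read-out lower numbers stand for stronger inhibition and higher numbers for weaker inhibition. Compound 1 `Cc1nc2cc(OC[C@H](O)CN3CCN(Cc4noc(-c5ccc(Cl)cc5)n4)CC3)ccc2s1` gives 2270 nM, compound 2 `Cc1nc2cc(OC[C@H](O)CN3CCN(Cc4csc(-c5ccc(C(F)(F)F)cc5)n4)CC3)ccc2s1` gives 1300 nM, and compound 3 `Cc1nc2cc(OC[C@H](O)CN3CCN(Cc4noc(-c5ccc(Cl)c(Cl)c5)n4)CC3)ccc2s1` gives 550 nM. Compound 3 therefore stands lowest of the three: compound 2 is the nearest and compound 1 the furthest, and both gaps lie beyond the scatter. Among the compounds with values here, the only step between compounds differing in one place is a 4.1-fold lower number from compound 1 to compound 3 (0.62 log units; beyond the scatter), a modest gain on adding a chloro.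

Compound 4 `Cc1cccc(-c2nc(CN3CCN(C[C@@H](O)COc4ccc5sc(C)nc5c4)CC3)no2)c1` differs from compound 3 by 3-methylphenyl in place of 3,4-dichlorophenyl on an aromatic carbon. Within the data shown here, this change removes the chloro whose arrival gave the gain in a 4.1-fold lower number from compound 1 to compound 3 (0.62 log units; beyond the scatter), removes the second chloro as well, and brings in a methyl for which no measured step exists in this assay. The reversal of the one measured gain points to a higher number for compound 4 than for compound 3; how far the methyl offsets the loss of the second chloro cannot be read from the three numbers, so the range is set wide. Compound 4 is expected to give 2200 nM in this assay, with a range from 700 nM to 7000 nM. The expected step is a 4.0-fold higher number from compound 3 to compound 4 (0.60 log units; beyond the scatter).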

Compound 4, half-maximal inhibitory concentration: 6500 nM
Compound 4: middle estimate off by 3.0-fold (0.47 log units), on the low side; low and high end bracket the measured number.
By their numbers in this assay, from the lowest: compound 3; then compounds 2 and 1 (each within the scatter of the next); then compound 4.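

Within the data shown here, with the aryl group on the five-membered aromatic ring with 2 nitrogen and 1 oxygen as the only change, this assay shows a 12-fold higher number from compound 3 to compound 4 (1.07 log units; beyond the scatter) as a large step, whereas the earlier step at this place, a 4.1-fold lower number from compound 1 to compound 3 (0.62 log units; beyond the scatter), was modest. The 3-methylphenyl group also falls short of the single-chloro 4-chlorophenyl group, with a 2.9-fold higher number from compound 1 to compound 4 (0.46 log units; beyond the scatter) beyond the scatter, so among these three oxygen-and-nitrogen-ring compounds the numbers rise from 3,4-dichlorophenyl through 4-chlorophenyl to 3-methylphenyl. Nothing on hand gives a reason for this order.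

The compounds shown leave open how much of the rise belongs to the departing chloro groups and how much to the entering methyl, as the change from compound 3 to compound 4 alters both at once. An unsubstituted phenyl, 3-chlorophenyl or 4-methylphenyl at this place would separate the identity of the substituent from its position on the aryl ring, and a 3,4-dimethylphenyl would test the methyl against the pattern of compound 3.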